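Swapping the Halogen on the Sugar Ring

This account rests on a few compounds, and the source may have more. Where it says the series, first, only, none or still open, it means among the compounds named here.

Compound 2 `Nc1ccn(C2OC(CO)C(I)C2O)c(=O)n1` is tested in a functional assay on P815 cells (Mus musculus) for antiproliferative activity; a higher number here means a weaker inhibitor, a lower number a stronger inhibitor. In this assay compound 2 gives only a limit, > 100 ug/mL. Its neighbour compound 1 `Nc1ccn(C2OC(CO)C(Br)C2O)c(=O)n1` likewise gives a limit, > 100 ug/mL. The step that the two limits leave unreadable from compound 1 to compound 2 therefore cannot be read, since both values sit at the limit of > 100 ug/mL in this assay, at which 2 of the 2 values shown sit. Compound 3 `Nc1ccn(C2OC(CO)C(Cl)C2O)c(=O)n1` changes compound 2 by chloro in place of iodo on a saturated ring carbon. Going by the values given here, no measured step can guide this change, as the one halogen swap seen so far ended at the limit on both sides. Compound 3 is therefore expected to behave the same way, with an estimated step that the limit leaves unreadable from compound 2 to compound 3 and an estimated value of 150 ug/mL, between 50 ug/mL and 500 ug/mL.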

Compound 3, concentration for 50% inhibition: > 100 ug/mL
Compound 3 gave a limit, no number; the forecaster's own chance of this, stated with the estimate: 85%; the middle value lies beyond the limit too.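

The steps from compound 1 and from compound 2 to compound 3 cannot be read, since all three compounds end at the same limit: the limit of > 100 ug/mL in this assay, at which 3 of the 3 values shown sit. In this assay, going by these compounds, it stays open whether bromo, iodo and chloro differ at all.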